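A few compounds are considered here, and "the series" means these few. Any claim that something is new, unique, unknown or untested is made for them only; others in the source may bear on it.

Compound 1 `CC[C@@H](C)[C@H](NC(=O)c1ccc(Oc2nc3ccccc3nc2C)cc1)C(=O)OC`: > 50000 nM (a limit of the assay)
Compound 2 `Cc1nc2ccccc2nc1Oc1ccc(C(=O)N[C@@H](C)C(=O)O)cc1`: 22300 nM

Among the measured compounds shown here, in a functional assay on HeLa cells (Homo sapiens) for antiproliferative activity, read by MTT assay, with a stated time of 48 h (a lower number here means a stronger inhibitor, a higher number a weaker inhibitor), compound 2 gives 22300 nM, the only actual number so far. Compound 1 has only a limit: the limit of > 50000 nM in this assay, at which 1 of the 2 values shown sits.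

Compound 3 `Cc1nc2ccccc2nc1Oc1ccc(C(=O)N[C@@H](CC(C)C)C(=O)O)cc1` differs from compound 2 by isopropyl in place of hydrogen on a saturated chain carbon, two bonds along the chain from an amide-type nitrogen and a carbonyl carbon; put another way, 1-carboxyethyl becomes 1-carboxy-3-methylbutyl. For the measured compounds named here, one measured step bears on this, an at least 2.2-fold lower number from compound 1 to compound 2 (0.35 log units; beyond the scatter). That step swaps 1-(methoxycarbonyl)-2-methylbutyl for 1-carboxyethyl, so it changes the chain and the ester together and does not size the isopropyl alone. Compound 3 keeps the carboxy group of compound 2, so only a weak lean towards a higher number is taken from that step. The step expected in this assay is a 1.1-fold higher number from compound 2 to compound 3 (0.05 log units; within the scatter), none beyond the scatter. For compound 3 the estimated value is 25000 nM, with an expected range of 10000 nM to 50000 nM.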

Compound 3, half-maximal inhibitory concentration: 17300 nM
The estimate for compound 3 lay 1.4-fold (0.16 log units) above the measured number; measured number inside the range.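

In this assay, isopropyl in place of hydrogen on this saturated chain carbon gives a 1.3-fold lower number from compound 2 to compound 3 (0.11 log units; within the scatter), so this assay does not separate 1-carboxyethyl from 1-carboxy-3-methylbutyl. Exchanging 1-(methoxycarbonyl)-2-methylbutyl for 1-carboxy-3-methylbutyl on the amide-type nitrogen gives an at least 2.8-fold lower number from compound 1 to compound 3 (0.46 log units; beyond the scatter), but that change alters the ester and the chain together. Compound 1 remains a limit of the assay and not a number: the limit of > 50000 nM in this assay, at which 1 of the 3 values shown sits.

The compounds shown leave open how much of the gap from compound 1 belongs to the ester alone, since no pair here differs only in that group. Also open, on these data alone, is how this assay reads a phenyl group or an amine on the same chain carbon, or a primary amide in place of the carboxy group.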